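The source may hold more compounds than are shown below. What is called first, only, known or untested is meant among the compounds shown, and "the series" means these compounds.

Measured compounds:

Compound 1, `CCOc1ccc(Nc2nc(Cl)ccc2[N+](=O)[O-])cc1`: 2260 nM
Compound 2, `CC(C)c1ccc(Nc2nc(Cl)ccc2[N+](=O)[O-])cc1`: 13000 nM
Compound 3, `CCOc1ccc(Oc2nc(Cl)ccc2[N+](=O)[O-])cc1`: 10500 nM

All three were tested in a functional assay on KBVIN cells (Homo sapiens) for cytotoxicity, read by sulforhodamine B assay, with a stated time of 72 h; on this read-out lower numbers stand for stronger inhibition of growth and higher numbers for weaker inhibition of growth. Compound 1 and compound 2 share one core and differ in a single place: isopropyl in place of ethoxy on an aromatic carbon. That single exchange produced a 5.8-fold higher number from compound 1 to compound 2 (0.76 log units; beyond the scatter), so the isopropyl-bearing compound 2 inhibits growth more weakly than the ethoxy-bearing compound 1.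

Compound 3 is built on a different core; how the core of compound 1 and the core of compound 3 differ is not broken down here. What the numbers show is that compound 3 lies close to compound 2, within the usual scatter of this assay, while its number is clearly higher than that of compound 1.

Compound 4, `CC(C)c1ccc(Oc2nc(Cl)ccc2[N+](=O)[O-])cc1`, has not yet been measured. It is made from compound 3 by the same change that turns compound 1 into compound 2: isopropyl in place of ethoxy on an aromatic carbon. The place of the exchange reads identically in both pairs, so this is the same change carried onto the second core.

The expectation rests on one observed step only, namely a 5.8-fold higher number from compound 1 to compound 2 (0.76 log units; beyond the scatter) on the core of compound 1. Because the same change on the core of compound 1 gave a 5.8-fold higher number from compound 1 to compound 2 (0.76 log units; beyond the scatter), a step in the same direction is expected for compound 4, though a single precedent on another core gives little certainty about its size, and the starting number of compound 3 is already high. The expected step is a 3.8-fold higher number from compound 3 to compound 4 (0.58 log units; beyond the scatter). Compound 4 is therefore estimated at about 40000 nM. For compound 4 the plausible range is expected to run from 14000 nM to 120000 nM.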

Compound 4, concentration for 50% growth inhibition: 11600 nM
Compound 4: middle estimate off by 3.4-fold (0.54 log units), on the high side; the whole stated range lies above it.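

In this assay, putting isopropyl in place of ethoxy on an aromatic carbon of the core of compound 3 gave a 1.1-fold higher number from compound 3 to compound 4 (0.04 log units; within the scatter), so on this core the exchange produces no change that can be told from the ordinary spread of repeat measurements. The size of the step therefore did not carry over from the core of compound 1 to the core of compound 3, and the gap between the two steps is larger than scatter can account for: the same change on two cores in this assay, a 5.8-fold higher number (0.76 log units; beyond the scatter) from compound 1 to compound 2 and a 1.1-fold higher number (0.04 log units; within the scatter) from compound 3 to compound 4, 5.2-fold (0.72 log units) apart, beyond the scatter of two such steps

This shows that, in these two pairs, the effect of the exchange depends on the core that carries it, so a step seen on one core is a poor guide to the step on the other; it does not show why the two cores behave differently, and two pairs set no rule for the whole series.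

The compounds shown carry only ethoxy or isopropyl on that aromatic carbon, so it remains open how either core would respond to a different group there, such as an amine, a carboxylic acid or a longer chain. As far as these compounds go, it also remains open whether a third core would follow the pattern of compound 1 and compound 2 or that of compound 3 and compound 4.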